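A few compounds are considered here, and "the series" means these few. Any claim that something is new, unique, unknown or untested is made for them only; others in the source may bear on it.

Compound 3 `CC(=O)C1CCC(Cn2c(-c3ccc(OCc4c(-c5c(Cl)cccc5Cl)noc4C(C)C)cc3)nc3ccc(C(=O)O)cc32)CC1` stands with the highest number of the three measured compounds in an assay on Huh-7 cells for agonist activity at Bile acid receptor (Homo sapiens), read by a luciferase reporter (on this read-out lower numbers stand for an effect already at smaller amounts and higher numbers for an effect only at larger amounts of compound), where compound 3 gives 1170 nM. Compound 1 `CC(C)c1onc(-c2c(Cl)cccc2Cl)c1COc1ccc(-c2nc3ccc(C(=O)O)cc3n2C2CC2)cc1` gives 16.5 nM, and compound 2 `CC(C)c1onc(-c2c(Cl)cccc2Cl)c1COc1ccc(-c2nc3ccc(C(=O)O)cc3n2C2CCCCCC2)cc1` gives 14.8 nM; these two lie within the scatter of each other, as seen in a 1.1-fold lower number from compound 1 to compound 2 (0.05 log units; within the scatter). Compound 4 `CC(C)c1onc(-c2c(Cl)cccc2Cl)c1COc1ccc(-c2nc3ccc(C(=O)O)cc3n2C2CCCC2)cc1` differs from compound 3 in one place: cyclopentyl in place of (4-acetylcyclohexyl)methyl on an aromatic nitrogen. Going by the values given here, two measured steps bear on this change, a 71-fold higher number from compound 1 to compound 3 (1.85 log units; beyond the scatter) and a 79-fold higher number from compound 2 to compound 3 (1.90 log units; beyond the scatter), and both were large. Because of a 71-fold higher number from compound 1 to compound 3 (1.85 log units; beyond the scatter) and a 79-fold higher number from compound 2 to compound 3 (1.90 log units; beyond the scatter), compound 4 is expected to move back toward the lower numbers, which means a 73-fold lower number from compound 3 to compound 4 (1.86 log units; beyond the scatter). The estimate for compound 4 in this assay is 16 nM, with a range from 6 nM to 45 nM.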

Compound 4, half-maximal effective concentration: 13.6 nM
For compound 4 the middle estimate is 1.2-fold (0.07 log units) above the measured one, and the stated range covers the measured number.
By their numbers in this assay, from the lowest: compounds 4, 2 and 1 (each within the scatter of the next); then compound 3.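

In this assay, swapping (4-acetylcyclohexyl)methyl for cyclopentyl on the aromatic nitrogen gives an 86-fold lower number from compound 3 to compound 4 (1.93 log units; beyond the scatter). The other two steps, a 1.1-fold lower number from compound 2 to compound 4 (0.04 log units; within the scatter) and a 1.2-fold lower number from compound 1 to compound 4 (0.08 log units; within the scatter), show that cyclopropyl, cyclopentyl and cycloheptyl cannot be told apart here, so ring size among these three makes no readable difference. No measurement shown explains why compound 3 stands apart.

On these data alone, it remains open whether the acetyl group, the methyl link or the six-membered ring accounts for the higher number of compound 3. A plain cyclohexylmethyl group or a straight butyl chain on this nitrogen would help separate these parts.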